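Replacing a chlorophenyl group in a fast-cleared compound

The source may report more compounds than this note shows. Statements on the series, on what has been measured and on what is new or still open speak of the compounds shown alone.

Compound 1 (`O=C(NCc1cc(Cl)ccc1-n1cnnn1)[C@@H]1C[C@@H]2C[C@@H]2N1C(=O)[C@H](O)c1cccc(Cl)c1`) is tested in an ADME assay on liver for metabolic stability, with Liver microsome (Homo sapiens) as the target, read by LC-MS, using microsomes (on this read-out higher numbers stand for fast clearance and lower numbers for slow clearance), and gives > 500 mL.min-1.g-1 as a limit of the assay, not a number. In this assay compound 2 (`Cc1cccc([C@@H](O)C(=O)N2N=CC[C@H]2C(=O)NCc2cc(Cl)ccc2-n2cnnn2)c1`) gives < 12 mL.min-1.g-1 as a limit too. Of these two compounds, compound 1 therefore stands at the fast-clearance end.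

Compound 3 (`CC(C)(C)OC[C@@H](O)C(=O)N1[C@H](C(=O)NCc2cc(Cl)ccc2-n2cnnn2)C[C@@H]2C[C@@H]21`) keeps the core of compound 1 but carries (tert-butoxy)methyl in place of 3-chlorophenyl on a saturated chain carbon bound to a carbonyl carbon and an oxygen on a saturated carbon. For the measured compounds named here, no measured pair of compounds isolates this exchange, so any forecast is loose. Compound 2 differs from compound 1 in more than one place, and it shows only that slow clearance can occur among these related structures. A move towards slower clearance is nevertheless expected, and the estimated size is an at least 3.3-fold lower number from compound 1 to compound 3 (0.52 log units; beyond the scatter) on this uncertain basis. The expected value for compound 3 is estimated at 150 mL.min-1.g-1 (range 40 mL.min-1.g-1 to 500 mL.min-1.g-1).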

Compound 3, intrinsic clearance in microsomes: 21 mL.min-1.g-1
The estimate for compound 3 lay 7.1-fold (0.85 log units) above the measured number; measured number outside the range, below it.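

In this assay, (tert-butoxy)methyl in place of 3-chlorophenyl, on a saturated chain carbon bound to a carbonyl carbon and an oxygen on a saturated carbon, gives an at least 23-fold lower number from compound 1 to compound 3 (1.37 log units; beyond the scatter). For the compounds shown here, compound 2 differs from compound 1 in more than one place, so this is the first comparison to show that a change in this one place, with the core of compound 1 kept, is enough to shift clearance by a large amount. The value for compound 1 is a limit of the assay and not a number, so the size of this step is only a minimum: the limit of > 500 mL.min-1.g-1 in this assay, at which 1 of the 3 values shown sits.

The exchange removes an aromatic ring and a chlorine and adds an ether oxygen and a branched tert-butyl end all at once, so the compounds shown cannot say which of these parts matters for the drop. A cyclohexyl group would show what happens when a ring stays but is no longer aromatic, and a methoxymethyl group would show whether the ether oxygen still goes with slow clearance without the tert-butyl end.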